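Pyridine Amide Replacing a Dichlorophenyl Amide on a Shared Core

The source may report more compounds than this note shows. Statements on the series, on what has been measured and on what is new or still open speak of the compounds shown alone.

Compound 1: `O=C(Nc1ccc(Cl)c(-c2nnc3c(Cl)cccn23)c1)c1ccccc1Cl` — > 100000 nM
Compound 2: `O=C(Nc1ccc(Cl)c(-c2nnc3c(Cl)cccn23)c1)c1ccc(Cl)cc1Cl` — > 100000 nM

The two measured compounds share one core and differ only in the group on the amide carbonyl. In a functional assay on HeLa cells (Homo sapiens) for antiproliferative activity, read by MTT assay, with a stated time of 72 h (on this read-out lower numbers stand for stronger inhibition and higher numbers for weaker inhibition), compound 1 gives no number but only a limit, > 100000 nM. Compound 2 likewise gives only a limit, > 100000 nM. The step that the two limits leave unreadable from compound 1 to compound 2 therefore cannot be read in size or direction, because the limit of > 100000 nM in this assay, at which 2 of the 2 values shown sit, covers both values.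

Compound 3 is `O=C(Nc1ccc(Cl)c(-c2nnc3c(Cl)cccn23)c1)c1ccccn1`. Its change from compound 2 is pyridin-2-yl in place of 2,4-dichlorophenyl on a carbonyl carbon. For the measured compounds named here, no measured step bears on this change, since the only measured step, chloro in place of hydrogen on an aromatic carbon, is itself unreadable. With both measured compounds sitting at the limit, the natural expectation is that compound 3 also shows weak or no inhibition, though a new group on the carbonyl leaves room for a real value to appear. Compound 3 is therefore expected to give 80000 nM, within a range from 10000 nM to 200000 nM. The estimated step of an at least 1.2-fold lower number from compound 2 to compound 3 (0.09 log units; that floor lies within the scatter) is thus expected to be small, if any.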

Compound 3, half-maximal inhibitory concentration: 75500 nM
Estimate against measurement, compound 3: 1.1-fold (0.03 log units) above; the range from low to high includes it.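

In this assay, for the compounds shown here, pyridin-2-yl on the carbonyl carbon gives compound 3 a value of 75500 nM, the first real number on the shared core rather than a limit, so this position can give a readable result. Replacing 2,4-dichlorophenyl with pyridin-2-yl gives an at least 1.3-fold lower number from compound 2 to compound 3 (0.12 log units; that floor lies within the scatter), and replacing 2-chlorophenyl with it gives an at least 1.3-fold lower number from compound 1 to compound 3 (0.12 log units; that floor lies within the scatter). From the compounds shown here alone, each of these is only a floor and lies within the scatter, so a real gain is not established, and the true size of both steps stays unknown because the two starting compounds carry a limit and not a number: the limit of > 100000 nM in this assay, at which 2 of the 3 values shown sit.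

The compounds shown leave open whether plain phenyl, with neither chlorine nor a ring nitrogen, would also give a number, so the result cannot be credited to the ring nitrogen rather than to the loss of the chloro groups. Also open, going by these compounds, is whether a carboxylic acid or an amine on the aromatic ring of the amide would move the number in this assay by more than the scatter.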